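Swapping Chloro for Cyano: Expecting Weaker Cytotoxicity

A few compounds are considered here, and "the series" means these few. Any claim that something is new, unique, unknown or untested is made for them only; others in the source may bear on it.

Of the compounds shown here, three with a shared amide core have been tested in an ADME assay on HEK293 cells (Homo sapiens) for cytotoxicity, read by MTT assay, with a stated time of 48 h; a higher number here means a weaker inhibitor, a lower number a stronger inhibitor. Among the measured compounds shown here, compound 3 `CCS(=O)(=O)Nc1ccc(NC(=O)c2ccc(Cl)cc2)cc1F` is the only one that gives a number: in this assay compound 3 shows 53400 nM. Compound 1 `CCS(=O)(=O)Nc1ccc(NC(=O)c2ccc(C#N)cc2)cc1Cl` carries a cyano group, and in this assay compound 1 reaches only the limit of the measurement, > 250000 nM. Compound 2 `CS(=O)(=O)Nc1ccc(NC(=O)c2ccc(C#N)cc2)cc1F` also carries a cyano group, and in this assay compound 2 likewise gives a limit, > 250000 nM. Compound 4 `CCS(=O)(=O)Nc1ccc(NC(=O)c2ccc(C#N)cc2)cc1F` is not yet measured. It differs from compound 3 in one place: cyano in place of chloro on an aromatic carbon. For the measured compounds named here, no measured pair differs in exactly this way, so the size of the step cannot be read directly from the data. Because of the limit of > 250000 nM in this assay, at which 2 of the 3 values shown sit, and because both compounds that already carry cyano sit at that limit, the step from compound 3 to compound 4 is expected to move toward weaker inhibition, by a 3.7-fold higher number from compound 3 to compound 4 (0.57 log units; beyond the scatter), which is beyond the usual scatter. Compound 4 is therefore estimated at 200000 nM, within a range from 80000 nM to 600000 nM, with a fair chance that only a limit is reported.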

Compound 4, half-maximal inhibitory concentration: 26400 nM
Compound 4: middle estimate off by 7.6-fold (0.88 log units), on the high side; the measured number lies below the stated range.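

In this assay, the change from 4-chlorophenyl to 4-cyanophenyl now has a measured direction and size, a 2.0-fold lower number from compound 3 to compound 4 (0.31 log units; beyond the scatter), so carrying cyano at this position does not by itself keep a compound free of a measurable cytotoxic effect. Among the three cyano compounds, the result also depends on changes elsewhere in the molecule, with an at least 9.4-fold lower number from compound 2 to compound 4 (0.97 log units; beyond the scatter) for methyl in place of hydrogen on the chain bound to the sulfonyl sulfur and an at least 9.4-fold lower number from compound 1 to compound 4 (0.97 log units; beyond the scatter) where fluoro replaces chloro. Compound 1 and compound 2 each stand at a limit of the assay and not at a number, so these two steps give only a minimum size: the limit of > 250000 nM in this assay, at which 2 of the 4 values shown sit.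

The compounds shown leave open whether another group at this position, such as an amine or a carboxylic acid, would give a higher or a lower number than chloro or cyano on the same core. It also remains open how far the two changes elsewhere in the molecule would shift a 4-chlorophenyl compound, as compound 3 is the only one shown.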